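Adding a Methyl to a Compound Already at the Limit

This account rests on a few compounds, and the source may have more. Where it says the series, first, only, none or still open, it means among the compounds named here.

Of the compounds shown here, three sharing one core have been measured in an assay for displacement of a labelled ligand from Sigma non-opioid intracellular receptor 1 (Cavia porcellus), read by scintillation counting; a lower number here means a stronger inhibitor, a higher number a weaker inhibitor. Compound 1 `NCC[C@@H]1CCO[C@H](c2ccccc2)O1` gives 165 nM in this assay. Compound 2 `CNCC[C@@H]1CCO[C@H](c2ccccc2)O1` gives 449 nM in this assay. Between them lies a single change, methyl in place of hydrogen on an amine nitrogen, and this assay records a 2.7-fold higher number from compound 1 to compound 2 (0.43 log units; beyond the scatter). Compound 3 `NCC[C@@H]1CCOC(c2ccccc2)(c2ccccc2)O1` differs from compound 1 by a second phenyl group on the core. In this assay compound 3 gives only > 10000 nM, which is a limit of the assay and not a number; it sits at the limit of > 10000 nM in this assay, at which 1 of the 3 values shown sits.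

Compound 4 `CNCC[C@@H]1CCOC(c2ccccc2)(c2ccccc2)O1` is not yet measured. It differs from compound 3 by methyl in place of hydrogen on an amine nitrogen, which is the same change as from compound 1 to compound 2. That step was modest and pointed toward a higher number. Applied to compound 3, which already sits at a limit, the same change is expected to give another limit rather than a number, and the expected step is a step that the limit leaves unreadable from compound 3 to compound 4. For compound 4 the expected value in this assay is 30000 nM, with a range from 10000 nM to 100000 nM.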

Compound 4, inhibition constant: > 10000 nM
Compound 4 ended at the assay's limit; the forecaster's own chance of this, stated with the estimate: 90%; the middle value does not contradict the limit.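

Compound 3 and compound 4 both sit at a limit of this assay and not at a number, so no step can be read between them: the limit of > 10000 nM in this assay, at which 2 of the 4 values shown sit.

The compounds shown leave open whether methyl in place of hydrogen on an amine nitrogen changes the value at all when the core carries the second phenyl group.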